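A few compounds are considered here, and "the series" means these few. Any claim that something is new, unique, unknown or untested is made for them only; others in the source may bear on it.

In a toxicity assay on MT4 cells (Homo sapiens) for cytotoxicity, read by MTT assay, with a stated time of 5 days (a higher number here means that more compound is tolerated, a lower number that less compound is tolerated), two compounds built on a shared core have been measured so far. Compound 1 `Cc1cc(-c2cncnc2)cc(C)c1Nc1ccnc(Nc2ccc(C#N)cc2)n1` gives 6800 nM, and compound 2 `Cc1cc(-c2ccnc(F)c2)cc(C)c1Nc1ccnc(Nc2ccc(C#N)cc2)n1` gives 6000 nM. The numbers for these two compounds lie within the scatter of each other, so neither can be said to be better tolerated.

The next compound to be measured is compound 3 `Cc1cc(-c2ccnc(C(F)(F)F)c2)cc(C)c1Nc1ccnc(Nc2ccc(C#N)cc2)n1`. It has trifluoromethyl in place of fluoro on an aromatic carbon, next to the ring nitrogen: trifluoromethyl in place of fluoro on an aromatic carbon. Going by the values given here, only one measured step can serve as a guide, namely a 1.1-fold lower number from compound 1 to compound 2 (0.05 log units; within the scatter), where 2-fluoropyridin-4-yl stands in place of pyrimidin-5-yl on an aromatic carbon. Among the compounds with values here, that is thin evidence, since no measured compound carries trifluoromethyl and the step exchanged a different pair of groups. Even so, with that one step as the only guide, no step beyond the scatter is expected in this assay. The estimated step is a 1.2-fold lower number from compound 2 to compound 3 (0.08 log units; within the scatter). For compound 3 the estimated value is 5000 nM, with an expected range from 2000 nM to 12000 nM.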

Compound 3, half-maximal cytotoxic concentration: 6100 nM
Estimate against measurement, compound 3: 1.2-fold (0.09 log units) below, and the stated range covers the measured number.
By their numbers in this assay, from the lowest: compounds 2, 3 and 1 (each within the scatter of the next).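

In this assay, replacing the fluoro with trifluoromethyl on the aromatic carbon next to the ring nitrogen gives a 1.0-fold higher number from compound 2 to compound 3 (0.01 log units; within the scatter) and so leaves no readable difference, even though the group grows from 1 heavy atom to 4. Going by these compounds alone, until now, only an exchange of one whole ring group for another had been seen; this is the first comparison in which the ring stays the same and only the group on it changes. Read together with a 1.1-fold lower number from compound 1 to compound 3 (0.05 log units; within the scatter), which also lies within the scatter, the three compounds form a flat set in which none can be called better or worse tolerated, and no measurement is at hand that could explain this flatness.

From the compounds shown here alone, what an amine, a carboxylic acid or a longer chain on this same carbon would do in this assay stays open, so it is unknown whether any group here can move the number beyond the scatter. The compounds also leave open how the number responds to changes elsewhere on the shared core, such as replacing the nitrile with an amide.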